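The source may report more compounds than this note shows. Statements on the series, on what has been measured and on what is new or still open speak of the compounds shown alone.

Measured compounds:
compound 1, `COc1cccc(/C=C/c2ccccc2O)c1`, 26 ug/mL
compound 2, `COc1ccccc1/C=C/c1ccc(O)cc1`, 24 ug/mL
compound 3, `COc1cccc(/C=C/c2ccccc2N)c1`, 21.2 ug/mL

The three measured compounds were tested in a functional assay on HT-29 cells (Homo sapiens) for inhibition, read by MTT assay, with a stated time of 2 days; on this read-out higher numbers stand for weaker inhibition and lower numbers for stronger inhibition. Compound 1 gives 26 ug/mL, compound 2 gives 24 ug/mL and compound 3 gives 21.2 ug/mL; all three lie within the scatter of one another, so no order among them can be read from these numbers.

Compound 1 and compound 3 differ in one place: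
amino in place of hydroxy on an aromatic carbon
This step, a 1.2-fold lower number from compound 1 to compound 3 (0.09 log units; within the scatter), is within the scatter.

Compound 2 and compound 1 are built from the same atoms joined differently; the difference between the two cores is not broken down here.

Compound 4, `COc1ccccc1/C=C/c1ccc(N)cc1`, has not yet been measured in this assay. It differs from compound 2 in this way:
amino in place of hydroxy on an aromatic carbon
This is the same kind of change as that from compound 1 to compound 3, though the place is not the same: there the amino sits ortho to a large group, here para to a large group.

Resting on compound 2 and its value 24 ug/mL, and on the small step seen between compound 1 and compound 3, a step of a 1.2-fold lower number from compound 2 to compound 4 (0.08 log units; within the scatter) is expected. Compound 4 is therefore estimated at 20 ug/mL in this assay, expected to fall between 12 ug/mL and 36 ug/mL.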

Compound 4, half-maximal inhibitory concentration: 22 ug/mL
The estimate for compound 4 lay 1.1-fold (0.04 log units) below the measured number, within the range that was stated.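

Carried to the core of compound 2, amino in place of hydroxy on an aromatic carbon gives in this assay a 1.1-fold lower number from compound 2 to compound 4 (0.04 log units; within the scatter). Set beside the same change on the core of compound 1, the two steps do not differ: the same change on two cores in this assay, a 1.2-fold lower number (0.09 log units; within the scatter) from compound 1 to compound 3 and a 1.1-fold lower number (0.04 log units; within the scatter) from compound 2 to compound 4, 1.1-fold (0.05 log units) apart, within the scatter of two such steps. In these two pairs, then, the change stays within the scatter on both cores, but that is agreement between two steps too small to read: it gives no direction for the change and makes no rule for the wider series.

The compounds shown leave open whether other groups in this place, such as a carboxylic acid, a nitrile or an acetamide, would move the number beyond the scatter. On these data alone, all four compounds keep the methoxy group, so what an ethoxy group or a longer chain in its place would do also remains open.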